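This account rests on a few compounds, and the source may have more. Where it says the series, first, only, none or still open, it means among the compounds named here.

Three esters were tested in a functional assay on the whole organism for inhibition, with Brassica rapa subsp. chinensis as the target, with a stated time of 3 days, tested at 100 ppm; a lower number here means less inhibition of growth, a higher number more inhibition of growth at the concentration tested. Compound 1 `CC(C)=CCC/C(C)=C/COC(=O)/C=C/c1ccc(Cl)cc1Cl` gives 26%, compound 2 `Cc1ccc(C(C)C)c(OC(=O)/C=C/c2ccc(Cl)cc2Cl)c1` gives 33%, and compound 3 `Cc1ccc(OC(=O)/C=C/c2ccc(C(C)C)cc2)c(C(C)C)c1` gives 39%. Compound 2 thus sits close to both of the others: its gap to compound 3 and its gap to compound 1 each fall within the usual scatter of this kind of measurement, so the three numbers cannot be told apart with confidence, and all of them point to modest inhibition at the concentration used.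

Compound 4 `Cc1ccc(C(C)C)c(OC(=O)/C=C/c2ccc(Cl)cc2)c1` has not yet been measured. It differs from compound 2 in one place: hydrogen in place of chloro on an aromatic carbon. Going by the values given here, no pair of measured compounds differs in exactly this way, so there is no measured step to lean on, and the three measured numbers lie close together without any clear trend. The expected step from compound 2 to compound 4 in this assay is therefore a number 5 percentage points lower from compound 2 to compound 4 (within the scatter), a change no larger than the scatter. Compound 4 is expected to give about 28%, within a range from 10% to 50%.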

Compound 4, percent growth inhibition at one concentration: 36%
The estimate for compound 4 lay 8 percentage points below the measured number; the range from low to high includes it.
By their numbers in this assay, from the lowest: compounds 1, 2, 4 and 3 (each within the scatter of the next, the first and the last beyond it).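

In this assay, swapping this chloro group for hydrogen gives a number 3 percentage points higher from compound 2 to compound 4 (within the scatter) and the two numbers cannot be told apart. Going by these compounds alone, this is the first pair of measured compounds that differ in only one place, so it gives the first direct look at this position, on an aromatic carbon ortho to a large group and meta to a chloro group. At this concentration, the chloro group there makes no difference that can be read beyond the scatter, and no measurement at hand accounts for this.

Still open, from the compounds shown here alone, is whether a different group at this position, such as a methoxy group or a nitrile, would separate from compound 2 beyond the scatter. Also open, going by these compounds, is what replacing the remaining chloro group of compound 4 with hydrogen would do.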